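Nitrooxy on the chain carbon of a quinazolinone sulfonamide

The compounds below may be only part of what the source reports. "The series", "measured", "known", "first", "only" and "open" are said of these compounds alone.

Measured so far:
- compound 1, `O=c1c2ccccc2nc(CO[N+](=O)[O-])n1NS(=O)(=O)c1ccccc1`: 34%
- compound 2, `CC(=O)Nc1ccc(S(=O)(=O)Nn2c(C)nc3ccccc3c2=O)cc1`: 59.2%

Both compounds were tested in a functional assay on the whole organism (strain Sprague-Dawley) for inhibition, with Rattus norvegicus as the target, read by paw edema, with stated times of 30 min and 3 h, at a dose of 80 mg/kg by the oral route; on this read-out lower numbers stand for less inhibition and higher numbers for more inhibition at the one dose given (going by the name of the read-out). Compound 1 gives 34% in this assay. Compound 2 gives 59.2% in this assay, the higher of the two numbers, and the gap to compound 1 lies beyond the scatter. Within the data shown here, the two compounds differ in more than one place, so no single step is read from that pair; only what their two values show is taken.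

Compound 3, `CC(=O)Nc1ccc(S(=O)(=O)Nn2c(CO[N+](=O)[O-])nc3ccccc3c2=O)cc1`, has not yet been tested in this assay. It differs from compound 2 by nitrooxy in place of hydrogen on a saturated chain carbon bound to an aromatic carbon. The same group is present in compound 1, yet compound 1 also carries a different sulfonyl part, so its lower value cannot be assigned to the nitrooxy group alone.

Among the measured compounds shown here, with no single-change step available, a small fall or no change beyond the scatter is expected for a number 9.2 percentage points lower from compound 2 to compound 3 (within the scatter). Compound 3 is expected to reach 50%, between 35% and 65%.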

Compound 3, a percentage reported as inhibition, in the whole organism at one dose (the size of the read-out at that dose, not a potency): 64.8%
The estimate for compound 3 lay 14.8 percentage points below the measured number; the measured number falls inside the stated range.
By their numbers in this assay, from the lowest: compound 1; then compounds 2 and 3 (each within the scatter of the next).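

In this assay, nitrooxy in place of hydrogen on a saturated chain carbon bound to an aromatic carbon gives a number 5.6 percentage points higher from compound 2 to compound 3 (within the scatter), so at this position the change from methyl to (nitrooxy)methyl leaves the read-out within the scatter. The other single change, acetamido in place of hydrogen on an aromatic carbon, gives a number 30.8 percentage points higher from compound 1 to compound 3 (beyond the scatter), which ties the low value of compound 1 to the missing acetamido group rather than to the nitrooxy group, something the earlier pair could not separate. No supporting measurement bears on either step, so both stand as observations only.

Open at the chain carbon is how a hydroxyl, an amine or a carboxylic acid would read there, and whether a longer chain carrying the nitrooxy group would stay within the scatter of compound 3. Also open, from the compounds shown here alone, is whether the acetamido step carries over to a compound with methyl on that chain carbon, and how an amine or a methoxy group would compare with acetamido on the aromatic carbon.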